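This account rests on a few compounds, and the source may have more. Where it says the series, first, only, none or still open, it means among the compounds named here.

Of the compounds shown here, two built on one shared core have been tested in a functional assay on MCF7 cells (Homo sapiens) for cytotoxicity, read by sulforhodamine B assay, with a stated time of 72 h; on this read-out lower numbers stand for stronger inhibition and higher numbers for weaker inhibition. Compound 1 `CC(=O)c1nn(-c2ccc(Cl)cc2)/c(=N/c2nc(-c3c(C)n(C)n(-c4ccccc4)c3=O)cs2)s1` does not produce a number in this assay: its result, > 100000 nM, is a limit of the measurement. Compound 2 `CCOC(=O)c1nn(-c2ccccc2)/c(=N/c2nc(-c3c(C)n(C)n(-c4ccccc4)c3=O)cs2)s1` likewise gives only a limit in this assay, > 100000 nM. Where compound 2 stands is therefore plain: it sits at the same boundary as the only other value shown, and the whole picture so far is the limit of > 100000 nM in this assay, at which 2 of the 2 values shown sit. Going by the values given here, no two measured compounds differ in just one place, so no single change has yet been tied to a shift in this read-out.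

Compound 3 `CCOC(=O)c1nn(-c2ccc(Cl)cc2)/c(=N/c2nc(-c3c(C)n(C)n(-c4ccccc4)c3=O)cs2)s1` has not been measured in this assay. Compared with compound 2, it carries chloro in place of hydrogen on an aromatic carbon. Because compound 2 gives > 100000 nM in this assay, there is no measured number from which a move could start, and the step from one to the other is expected to be none beyond the scatter, a step that the limit leaves unreadable from compound 2 to compound 3. Compound 3 is therefore expected to come out at about 150000 nM, with a plausible range of 50000 nM to 500000 nM, most likely reported once more only as a limit.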

Compound 3, half-maximal inhibitory concentration: > 100000 nM
Compound 3 ended at the assay's limit; the forecaster's own chance of this, stated with the estimate: 85%; the middle value does not contradict the limit.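

Compound 3 gives only a limit in this assay, as do compound 1 and compound 2, so neither the change from compound 2 to compound 3 nor that from compound 1 to compound 3 can be read as a step. All results shown stand at one boundary: the limit of > 100000 nM in this assay, at which 3 of the 3 values shown sit.

The compounds shown leave open whether any change to the shared core gives a measurable number in this assay.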